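The source may hold more compounds than are shown below. What is called first, only, known or untested is meant among the compounds shown, and "the series" means these compounds.

Measured compounds:
- Compound 1, `Cc1nc(N2CCN(S(C)(=O)=O)CC2)nc2ccc(NC(=O)COc3ccc(Cl)cc3)cc12`, in a functional assay on CHO-K1 cells for antagonist activity at melanin-concentrating hormone receptor 1 (Homo sapiens), read by inositol phosphate accumulation (a lower number here means a stronger inhibitor, a higher number a weaker inhibitor), gives > 10000 nM, which is a limit of the assay and not a number.
- Compound 2, `Cc1nc(N2CCN(C3CCOCC3)CC2)nc2ccc(NC(=O)COc3ccc(OC(F)(F)F)cc3)cc12`, in this assay gives 31 nM.
- Compound 3, `Cc1nc(N2CCN(C(=O)C3CCC3)CC2)nc2ccc(NC(=O)COc3ccc(OC(F)(F)F)cc3)cc12`, in this assay gives 45 nM.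

Going by these compounds, compound 1 thus stands at the limit of > 10000 nM in this assay, at which 1 of the 3 values shown sits, so its true value is unknown beyond that boundary. Compounds 2 and 3 both give numbers well inside the measurable range, and the step of a 1.5-fold higher number from compound 2 to compound 3 (0.16 log units; within the scatter) shows that swapping the group on the ring nitrogen in that pair left the result essentially unchanged.

Compound 4, `Cc1nc(N2CCN(CC(C)(C)C)CC2)nc2ccc(NC(=O)COc3ccc(Cl)cc3)cc12`, differs from compound 1 in one place: neopentyl in place of methylsulfonyl on an amine nitrogen in a ring. This is the same position that was varied from compound 2 to compound 3, but here the methylsulfonyl of compound 1 gives way to a neopentyl, a group unlike either of those two. Compounds 2 and 3 show that this ring nitrogen tolerates different substituents while keeping good potency, whereas the methylsulfonyl of compound 1 sits at the limit. Among the compounds with values here, no measured step connects compound 1 itself to a numbered value, so the size of the change is uncertain. Compound 4 is therefore expected to move off the limit, with an estimated step of an at least 120-fold lower number from compound 1 to compound 4 (2.09 log units; beyond the scatter), and an estimated value of 80 nM in this assay, in the range 15 nM to 600 nM.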

Compound 4, half-maximal inhibitory concentration: 246 nM
For compound 4 the middle estimate is 3.1-fold (0.49 log units) below the measured one; low and high end bracket the measured number.
By their numbers in this assay, from the lowest: compounds 2 and 3 (each within the scatter of the next); then compound 4. At a limit, above all of these: compound 1.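

With the rest of the molecule unchanged, the change on the amine nitrogen in the ring gives an at least 40-fold lower number from compound 1 to compound 4 (1.60 log units; beyond the scatter) in this assay, a large step. The value of compound 1 is a limit of the assay and not a number, which makes this step only a minimum for the true difference: the limit of > 10000 nM in this assay, at which 1 of the 4 values shown sits. The earlier pair, compound 2 and compound 3, showed two different groups at this nitrogen giving numbers within the scatter of each other, whereas this pair shows that the choice of group here can also decide whether a compound gives a measurable number at all.

Which feature of the swap matters remains open: only methylsulfonyl and neopentyl are compared on this version of the core, and they differ in several counted ways at once, in their atoms, double bonds and hydrogen-bond acceptors. A methyl group, an acetyl group or a plain hydrogen on the same nitrogen, with everything else as in compound 4, would help to show whether the sulfonyl group or the size of the carbon chain accounts for the step.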